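Swapping Chloro for Methyl on a Second Core

The source may report more compounds than this note shows. Statements on the series, on what has been measured and on what is new or still open speak of the compounds shown alone.

Compound 1, `Clc1cc(N2CC[C@@H]3CN[C@@H]3C2)cnc1Cl`: 110 nM
Compound 2, `Cc1cc(N2CC[C@@H]3CN[C@@H]3C2)cnc1Cl`: 71 nM
Compound 3, `Clc1cc(N2C[C@@H]3CCNC[C@@H]32)cnc1Cl`: 4110 nM

All three were tested in a functional assay on HEK293 cells for agonist activity at Neuronal acetylcholine receptor; alpha3/beta4 (Homo sapiens), read by FLIPR; a higher number here means that more compound is needed for the effect, a lower number that less compound is needed. Compounds 1 and 2 share one core, and the change between them, (methyl in place of chloro on an aromatic carbon), gave a 1.5-fold lower number from compound 1 to compound 2 (0.19 log units; within the scatter). Compound 3 has the same atoms as compound 1 joined differently; the difference between the two cores is not broken down here. In this assay compound 3 gives 4110 nM, the highest of the three numbers, and its distance from compound 1 and from compound 2 is beyond the scatter. Compound 4, `Cc1cc(N2C[C@@H]3CCNC[C@@H]32)cnc1Cl`, has not yet been measured in this assay. It carries the same change on the core of compound 3: methyl in place of chloro on an aromatic carbon. The step expected here, a 1.5-fold lower number from compound 3 to compound 4 (0.18 log units; within the scatter), rests on a 1.5-fold lower number from compound 1 to compound 2 (0.19 log units; within the scatter), the same change at the same place. Compound 4 is therefore estimated at 2700 nM, with a range from 1000 nM to 8000 nM.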

Compound 4, half-maximal effective concentration: 1910 nM
Compound 4: middle estimate off by 1.4-fold (0.15 log units), on the high side, within the range that was stated.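

On the core of compound 3, methyl in place of chloro gave a 2.2-fold lower number from compound 3 to compound 4 (0.33 log units; beyond the scatter) in this assay. Set beside the same change on the core of compound 1, the two steps point the same way and do not differ by more than the scatter: the same change on two cores in this assay, a 1.5-fold lower number (0.19 log units; within the scatter) from compound 1 to compound 2 and a 2.2-fold lower number (0.33 log units; beyond the scatter) from compound 3 to compound 4, 1.4-fold (0.14 log units) apart, within the scatter of two such steps. So the change behaved alike on these two cores, but two pairs do not make a rule for other cores, and they do not show why the number moves.

The compounds shown carry only chloro or methyl at this place on the aromatic ring. From the compounds shown here alone, what a larger or different group there, such as a methoxy group, a nitrile or an amine, would do remains open.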